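The source may hold more compounds than are shown below. What is called first, only, known or untested is meant among the compounds shown, and "the series" means these compounds.

Three compounds share one core and were looked at for inhibition of the enzyme. Compound 1 `O=C(Cc1ccncc1)c1cc2ccccc2[nH]1` was tested in an in vitro assay on P815B cells for inhibition of Indoleamine 2,3-dioxygenase 1 (Mus musculus), tested at 20 uM (a lower number here means less inhibition, a higher number more inhibition at the concentration tested (going by the name of the read-out)), and is recorded as "not active" (no number reported). Compound 2 `O=C(Cc1cccnc1)c1cc2ccccc2[nH]1`, tested in this assay, gives 13%. For compound 3 `COc1ccc2[nH]c(C(=O)Cc3cccnc3)cc2c1` the entry in this assay reads "not determined" (no result reported), so no result exists for it. Compound 2 therefore stands as the only one of the three with an actual number; the other two entries carry no single number at all.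

Compound 4 `Cn1c(C(=O)Cc2cccnc2)cc2ccccc21` has not yet been measured. It differs from compound 2 in a single place: methyl in place of hydrogen on an aromatic nitrogen. Among the measured compounds shown here, no pair of measured compounds that differ in one place exists here, so nothing in the data shows how a change of this kind moves the read-out. Given that compound 2 gives only 13%, the step expected in this assay is a number 3 percentage points lower from compound 2 to compound 4 (within the scatter), which is none beyond the scatter. Compound 4 is expected to give about 10%, within a range from 0% to 25%.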

Compound 4, a percentage reported as inhibition, at one concentration (the size of the read-out at that concentration, not a potency): "not active" (no number reported)
Compound 4: no number reported; the estimate stays without a comparison.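

In this assay, among the compounds shown here, compound 4 reads "not active" (no number reported), so no step from compound 2 to compound 4 can be read. The compounds shown leave open how far methyl in place of hydrogen on the aromatic nitrogen moves inhibition. Nothing shown here bears on this result.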